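From Dichlorobenzyl to Difluorobenzyl: One More Antiproliferative Test

A few compounds are considered here, and "the series" means these few. Any claim that something is new, unique, unknown or untested is made for them only; others in the source may bear on it.

Among the compounds with values here, in a functional assay on MCF cells (Homo sapiens) for antiproliferative activity, with a stated time of 72 h (a higher number here means a weaker inhibitor, a lower number a stronger inhibitor), compound 2 (`OC[C@H]1O[C@@H](n2cnc3c(NCc4ccc(Cl)c(Cl)c4)ncnc32)[C@H](O)[C@@H]1O`) gives 88800 nM as the only true number so far. Compound 1 (`OC[C@H]1O[C@@H](n2cnc3c(NCc4ccccc4Br)ncnc32)[C@H](O)[C@@H]1O`) gives > 166000 nM as its result, and this is a limit of the assay and not a number.

Compound 3 (`OC[C@H]1O[C@@H](n2cnc3c(NCc4ccc(F)cc4F)ncnc32)[C@H](O)[C@@H]1O`) keeps the shared core of compound 2 and alters a single group, the one on a saturated chain carbon bound to a nitrogen on an aromatic ring: 2,4-difluorophenyl in place of 3,4-dichlorophenyl on a saturated chain carbon bound to a nitrogen on an aromatic ring sums up the exchange, with 2,4-difluorophenyl in place of 3,4-dichlorophenyl.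

Within the data shown here, only one measured step touches this same place: an at least 1.8-fold lower number from compound 1 to compound 2 (0.27 log units; that floor lies within the scatter) gives a floor on its size rather than a full size, and that floor stays within the usual scatter of repeated measurements. With so little to go on, no step beyond the scatter is expected in this assay for the new exchange, and no direction can be favoured with confidence. An estimated 1.2-fold higher number from compound 2 to compound 3 (0.09 log units; within the scatter) is expected here and would lie within that scatter. Compound 3 is estimated at 110000 nM and is expected to fall between 45000 nM and 220000 nM.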

Compound 3, half-maximal inhibitory concentration: > 166000 nM
Compound 3: a limit, no number; the forecaster's own chance of this, stated with the estimate: 35%; middle value at least 1.5-fold (0.17 log units) away from the limit.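

In this assay, going by these compounds, the exchange of 3,4-dichlorophenyl for 2,4-difluorophenyl gives an at least 1.8-fold higher number from compound 2 to compound 3 (0.27 log units; that floor lies within the scatter); this is only a floor on the size of the step, so the true distance between the two compounds stays unknown. The step from compound 1 to compound 3 cannot be read at all, as both of its ends are limits. Within the data shown here, what is new is that the limit does not belong to the 2-bromophenyl group alone: it returns with a phenyl group carrying two fluorines, so only one of the three groups tried at this place gives a true number, and the results gather at a single ceiling: the limit of > 166000 nM in this assay, at which 2 of the 3 values shown sit.

The compounds shown leave open whether any group on a saturated chain carbon bound to a nitrogen on an aromatic ring can bring the number far under that of compound 2, which gives 88800 nM. An amine or a carboxylic acid on the phenyl ring, or a longer chain carrying that ring, would be further changes to test at this place.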